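The source may report more compounds than this note shows. Statements on the series, on what has been measured and on what is new or still open speak of the compounds shown alone.

For the measured compounds named here, in an assay on isolated protein for inhibition of Nicotinamide phosphoribosyltransferase (Homo sapiens), read by mass spectrometry, with stated times of 15 min and 30 min (a higher number here means a weaker inhibitor, a lower number a stronger inhibitor), compound 2 `O=C(NCc1ccc(S(=O)(=O)C2CCCOC2)cc1)N1Cc2ccncc2C1` gives 44 nM, the highest of the two numbers so far. Going by the values given here, its nearest neighbour is compound 1 `CCCn1cc(S(=O)(=O)c2ccc(CNC(=O)N3Cc4ccncc4C3)cc2)cn1`, which in this assay gives 17 nM; the only measured step, a 2.6-fold higher number from compound 1 to compound 2 (0.41 log units; beyond the scatter), exchanges the group on the sulfonyl sulfur and lies beyond the scatter. Compound 3 `O=C(NCc1ccc(S(=O)(=O)N2CCC(O)CC2)cc1)N1Cc2ccncc2C1` has not yet been measured in this assay. It differs from compound 2 at that same sulfonyl sulfur: 4-hydroxypiperidin-1-yl in place of oxan-3-yl on a sulfonyl sulfur. The step from compound 1 to compound 2 is the only one that bears on this change, and it was modest, so a second exchange at the sulfonyl sulfur is expected to give a step of comparable size, with no direction that the present numbers can fix. Compound 3 is therefore expected to show a 1.4-fold higher number from compound 2 to compound 3 (0.13 log units; within the scatter) in this assay. The estimate for compound 3 in this assay is 60 nM, with a range from 20 nM to 180 nM.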

Compound 3, half-maximal inhibitory concentration: 44 nM
For compound 3 the middle estimate is 1.4-fold (0.13 log units) above the measured one, within the range that was stated.
By their numbers in this assay, from the lowest: compound 1; then compounds 2 and 3 (each within the scatter of the next).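

In this assay the exchange of oxan-3-yl for 4-hydroxypiperidin-1-yl gives no change at the digits printed from compound 2 to compound 3 (within the scatter) even though the entering group adds a ring nitrogen and a hydrogen-bond donor, so these two six-membered non-aromatic rings cannot be told apart at the sulfonyl sulfur. The exchange of 1-propyl-1H-pyrazol-4-yl for 4-hydroxypiperidin-1-yl gives a 2.6-fold higher number from compound 1 to compound 3 (0.41 log units; beyond the scatter) and thus matches the earlier gap, which now separates compound 1 from two different non-aromatic rings rather than from one. No independent evidence bears on this result. Still open, on these data alone, is whether the hydroxyl of compound 3 contributes at all, which a plain piperidin-1-yl on the same sulfur could test. As far as these compounds go, it is also open whether an open-chain amine, a carboxylic acid or a pyrazole with a longer chain would move the number.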